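The source may hold more compounds than are shown below. What is called first, only, known or untested is meant among the compounds shown, and "the series" means these compounds.

In an ADME assay on a cell-free system (plasma, Homo sapiens) for metabolic stability, read by LC-MS, with a stated time of 60 min, tested at 10 uM (on this read-out higher numbers stand for a more stable compound and lower numbers for a less stable compound), compound 3 (`Cc1oc(=O)oc1COC(=O)N[C@@H](CCC(=O)C=[N+]=[N-])C(=O)OC(C)C`) gives 0% and stands level with compound 2 (`CCOC(=O)[C@H](CCC(=O)C=[N+]=[N-])NC(=O)OCc1oc(=O)oc1C`) at 0% as together the lowest of the three numbers. Compound 1 (`CC(C)[C@H](N)C(=O)N[C@@H](CCC(=O)C=[N+]=[N-])C(=O)OCc1c[nH]c2ccccc12`) stands furthest away at 30% on the same read-out, beyond the scatter, but it differs from compound 3 in more than one place and says little about a single exchange.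

Compound 4 (`CC(C)OC(=O)[C@H](CCC(=O)C=[N+]=[N-])NC(=O)OCOC(=O)C(C)(C)C`) has not yet been measured. Compared with compound 3 it carries a group of 7 heavy atoms (5 carbon, 2 oxygen; no ring) in place of a group of 7 heavy atoms (4 carbon, 3 oxygen; one five-membered aromatic ring with 2 hetero atoms), on a saturated chain carbon bound to an oxygen next to a carbonyl group and the entering group is ((tert-butyl)carbonyl)oxy.

Within the data shown here, the one measured step between compounds that differ in a single place is no change at the digits printed from compound 2 to compound 3 (within the scatter) and it lies within the scatter. Among the measured compounds shown here, that step is a methyl in place of hydrogen, so no measured step touches the group exchanged here. With compound 3 at 0% and no evidence from this place, no step beyond the scatter is expected in this assay and the estimated move is a number 4 percentage points higher from compound 3 to compound 4 (within the scatter) at most a small rise. For compound 4 the expected value is 4% with an estimated range from 0% to 20% on thin evidence.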

Compound 4, percent of the compound remaining: 9%
For compound 4 the middle estimate is 5 percentage points below the measured one; measured number inside the range.
By their numbers in this assay, from the lowest: compounds 2, 3 and 4 (each within the scatter of the next); then compound 1.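

In this assay, the exchange on a saturated chain carbon bound to an oxygen next to a carbonyl group gives a number 9 percentage points higher from compound 3 to compound 4 (within the scatter). Among these compounds, this is the first reading at this place, as the earlier single step concerned a methyl in place of hydrogen and did not touch this group. It shows that the group carrying the five-membered aromatic ring and the open-chain group with ((tert-butyl)carbonyl)oxy cannot be told apart on this read-out, although compound 3, at 0%, starts from the bottom of the scale and nothing in these data accounts for the reading.

The compounds shown leave open whether any group at this place would give a reading beyond the scatter, for instance a smaller acetyloxy, a longer chain ending in a carboxylic acid, or an amine. They also leave open whether ((tert-butyl)carbonyl)oxy would read the same on a core with another ester, such as the ethyl ester of compound 2, so the result so far holds for this one exchange on this one core.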